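Extending the Amide Arm: Expected Tolerance in Cells

The compounds below may be only part of what the source reports. "The series", "measured", "known", "first", "only" and "open" are said of these compounds alone.

The account follows tolerance in an ADME assay on HELF cells (Homo sapiens) for cytotoxicity, with a stated time of 3 days; a lower number here means that less compound is tolerated, a higher number that more compound is tolerated. Going by the values given here, compound 1 `CC(C)C[C@H](NC(=O)[C@]1(Cc2ccccc2)CCN1C(=O)OCc1ccccc1)C(N)=O` gives 50000 nM in this assay, and this is the only plain number in the set. Compound 2 `C[C@H](NC(=O)[C@@]1(Cc2ccccc2)CCN1C(=O)OCc1ccccc1)C(=O)N(C)C` gives > 100000 nM, which is a limit of the assay and not a number. Among the compounds with values here, the only further point of reference is the limit of > 100000 nM in this assay, at which 1 of the 2 values shown sits, so no measured step between compounds that differ in a single place exists here.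

Compound 3 `CC(C)CNC(=O)[C@H](C)NC(=O)[C@]1(Cc2ccccc2)CCN1C(=O)OCc1ccccc1` has not yet been measured. It differs from compound 1 by 1-(isobutylcarbamoyl)ethyl in place of 1-carbamoyl-3-methylbutyl on an amide-type nitrogen. Within the data shown here, with no measured step to lean on, the step from compound 1 to compound 3 is expected to be small, no larger than the scatter, a 1.2-fold higher number from compound 1 to compound 3 (0.08 log units; within the scatter). Compound 3 is therefore estimated at 60000 nM, within a range from 20000 nM to 180000 nM.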

Compound 3, half-maximal cytotoxic concentration: > 100000 nM
Compound 3 ended at the assay's limit (the forecaster's own chance of this, stated with the estimate: 40%); middle value at least 1.6-fold (0.22 log units) from the limit.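

Going by these compounds alone, the change of 1-carbamoyl-3-methylbutyl to 1-(isobutylcarbamoyl)ethyl on an amide-type nitrogen gives the first step that can be read at this position: an at least 2.0-fold higher number from compound 1 to compound 3 (0.30 log units; that floor lies within the scatter). That step is only a floor, so it shows that the extended arm with its isobutyl amide keeps the value of compound 3 at a limit of this assay, but it does not show how large the true change is. The set now has more values at that limit than plain numbers: the limit of > 100000 nM in this assay, at which 2 of the 3 values shown sit.

The compounds shown leave open how much compound is tolerated beyond this limit, so the real distance from compound 1 remains unknown. They also leave open whether a longer chain, an amine or a carboxylic acid at the end of this arm would bring the value back within the range of the assay.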